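Adding a Second Methoxy Group to Compound 1

A few compounds are considered here, and "the series" means these few. Any claim that something is new, unique, unknown or untested is made for them only; others in the source may bear on it.

Compound 1 `COc1ccc(-c2cc(/C=C/C(=O)c3ccc(N)cc3)[nH]n2)cc1` was tested in a functional assay on HT-29 cells (Homo sapiens) for inhibition, read by sulforhodamine B assay, with a stated time of 48 h (a lower number here means a stronger inhibitor of growth, a higher number a weaker inhibitor of growth), where compound 1 gives 2750 nM. Among the two compounds measured so far this is the higher number; the other, compound 2 `COc1cc(-c2cc(/C=C/C(=O)c3ccc(Cl)c(Cl)c3)[nH]n2)cc(OC)c1OC`, gives 1150 nM in this assay, and that gap lies beyond the usual scatter. Compound 2 differs from compound 1 in more than one place, so its number says nothing on its own about any single change. The new compound, compound 3 `COc1ccc(-c2cc(/C=C/C(=O)c3ccc(N)cc3)[nH]n2)cc1OC`, is compound 1 with one change: methoxy in place of hydrogen on an aromatic carbon. For the measured compounds named here, no pair of measured compounds shows the effect of exactly this change, so any expectation rests on compound 1 alone. A step from compound 1 to compound 3 of a 1.4-fold lower number from compound 1 to compound 3 (0.14 log units; within the scatter) is expected, small enough to sit within the scatter. Compound 3 is therefore estimated at 2000 nM, with a range from 700 nM to 6000 nM.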

Compound 3, concentration for 50% growth inhibition: 2600 nM
The estimate for compound 3 lay 1.3-fold (0.11 log units) below the measured number, within the range that was stated.
By their numbers in this assay, from the lowest: compound 2; then compounds 3 and 1 (each within the scatter of the next).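

In this assay, for the compounds shown here, the effect of this single change can now be read directly for the first time: methoxy in place of hydrogen on an aromatic carbon, ortho to a methoxy group, gives a 1.1-fold lower number from compound 1 to compound 3 (0.02 log units; within the scatter). In this one pair, then, the added methoxy group, with its 2 heavy atoms, makes no difference that can be told apart from the scatter. Nothing available here explains this result.

Going by these compounds, it remains open whether a different group at this place, such as an amine, a carboxylic acid or a longer ether chain, would shift the number beyond the scatter. On these data alone, it is also open whether the same methoxy change would stay this small on a compound that differs elsewhere from compound 1.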